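The source may report more compounds than this note shows. Statements on the series, on what has been measured and on what is new or still open speak of the compounds shown alone.

Values measured in an ADME assay on HEK293 cells (Homo sapiens) for cytotoxicity, read by WST assay; on this read-out higher numbers stand for lower toxicity in this test and lower numbers for higher toxicity in this test:
- compound 1 `CC1(C)CCC(C)(C)c2cc(C(=O)NCc3ccc(C=O)cc3)ccc21`: 49000 nM
- compound 2 `CC(C)(C)c1cccc(C(=O)OCc2ccc(C=O)cc2)c1`: 73000 nM
- compound 3 `O=C(OCc1ccc(B(O)O)cc1)c1cc(C(F)(F)F)cc(C(F)(F)F)c1`: 49000 nM

These three values all lie within the usual scatter of one another. Compound 3 reads the same as compound 1 at the digits shown, and compound 2 is not clearly separated from either, so no real difference can be read among them.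

The next molecule, compound 4 `NC(=O)c1ccc(COC(=O)c2cc(C(F)(F)F)cc(C(F)(F)F)c2)cc1`, keeps most of compound 3. On an aromatic carbon, para to a large group, the group holding boron gives way to carbamoyl (a group of 3 heavy atoms (1 carbon, 1 nitrogen, 1 oxygen; no ring) in place of a group of 3 heavy atoms (1 boron, 2 oxygen; no ring), on an aromatic carbon).

For the measured compounds named here, no measured pair shows this change on its own, so any forecast in this assay is only loosely anchored. It rests on compound 2 at 73000 nM and compound 3 at 49000 nM sitting so close together. The expected 1.3-fold higher number from compound 3 to compound 4 (0.12 log units; within the scatter) is small, slightly upward and within the scatter. For compound 4 the estimated value is 65000 nM, with an expected range of 30000 nM to 140000 nM.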

Compound 4, half-maximal cytotoxic concentration: > 100000 nM
Compound 4: a limit, no number; the forecaster's own chance of this, stated with the estimate: 30%; middle value at least 1.5-fold (0.18 log units) away from the limit.
By their numbers in this assay, from the lowest: compounds 1, 3 and 2 (each within the scatter of the next). At a limit, above all of these: compound 4.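

In this assay compound 4 reads > 100000 nM and this entry is a limit of the assay, not a number. For the compounds shown here, replacing the group holding boron with carbamoyl, on an aromatic carbon para to a large group, gives an at least 2.0-fold higher number from compound 3 to compound 4 (0.30 log units; that floor lies within the scatter) and this is the only single-place change available here, so it offers the first direct look at this position. From the compounds shown here alone, it shows that carbamoyl at this place does not bring the reading down from that of compound 3, but the true size of the step stays unknown because the reading for compound 4 is a limit: the limit of > 100000 nM in this assay, at which 1 of the 4 values shown sits.

Still open, going by these compounds, is how other groups at this place would read, such as a carboxylic acid, an amine or a nitrile. On these data alone, it is also open whether carbamoyl would give a similar step on the core of compound 1 or compound 2.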